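This account rests on a few compounds, and the source may have more. Where it says the series, first, only, none or still open, it means among the compounds named here.

Of the compounds shown here, three built on one shared core have been measured in a functional assay on HT-29 cells (Homo sapiens) for cytotoxicity, read by MTT assay, with a stated time of 72 h; on this read-out lower numbers stand for stronger inhibition and higher numbers for weaker inhibition. Compound 1 `CN(C)CCn1cnnc1-c1cc(Oc2ccc(NC(=O)N/N=C/c3ccc(Cl)cc3)cc2F)ccn1` gives 530 nM, compound 2 `CN(C)CCn1cnnc1-c1cc(Oc2ccc(NC(=O)N/N=C/c3cccc(Cl)c3Cl)cc2F)ccn1` gives 130 nM, and compound 3 `CN(C)CCn1cnnc1-c1cc(Oc2ccc(NC(=O)N/N=C/c3c(O)ccc4ccccc34)cc2F)ccn1` gives 670 nM. Compound 3 stands at the highest of the three numbers, though the gap a 1.3-fold higher number from compound 1 to compound 3 (0.10 log units; within the scatter) lies within the scatter, while the gap a 5.2-fold higher number from compound 2 to compound 3 (0.71 log units; beyond the scatter) is a modest step beyond it. Compound 4 `CN(C)CCn1cnnc1-c1cc(Oc2ccc(NC(=O)N/N=C/c3c(Cl)cccc3Cl)cc2F)ccn1` differs from compound 3 in one place: 2,6-dichlorophenyl in place of 2-hydroxynaphthalen-1-yl on a carbon with a double bond to nitrogen. Among the compounds with values here, two measured steps bear on this change. The step of a 4.1-fold lower number from compound 1 to compound 2 (0.61 log units; beyond the scatter) accompanied the change from 4-chlorophenyl to 2,3-dichlorophenyl, and the step of a 5.2-fold higher number from compound 2 to compound 3 (0.71 log units; beyond the scatter) accompanied the change from 2,3-dichlorophenyl to 2-hydroxynaphthalen-1-yl. Returning to a dichlorophenyl, though a 2,6-dichlorophenyl rather than the 2,3-dichlorophenyl of compound 2, leads one to expect a lower number for compound 4 in this assay, a step of about a 3.0-fold lower number from compound 3 to compound 4 (0.48 log units; beyond the scatter). Compound 4 is therefore estimated at 220 nM, with a range from 80 nM to 600 nM.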

Compound 4, half-maximal inhibitory concentration: 280 nM
Compound 4: the middle estimate sits 1.3-fold (0.10 log units) below what was measured; low and high end bracket the measured number.
By their numbers in this assay, from the lowest: compound 2; then compounds 4, 1 and 3 (each within the scatter of the next, the first and the last beyond it).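

In this assay the change from 2-hydroxynaphthalen-1-yl to 2,6-dichlorophenyl on a carbon with a double bond to nitrogen lowers the number (a 2.4-fold lower number from compound 3 to compound 4 (0.38 log units; beyond the scatter)), yet 2,6-dichlorophenyl in place of 2,3-dichlorophenyl raises it (a 2.2-fold higher number from compound 2 to compound 4 (0.33 log units; beyond the scatter)), so two chlorines on the phenyl do not by themselves reproduce compound 2. Set against 4-chlorophenyl, 2,6-dichlorophenyl cannot be told apart (a 1.9-fold lower number from compound 1 to compound 4 (0.28 log units; within the scatter)), which leaves 2,3-dichlorophenyl as the only chlorinated group here that stands clear of 4-chlorophenyl. No measurement is at hand that explains these differences.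

The compounds shown leave open whether 2,3-difluorophenyl would follow 2,3-dichlorophenyl at this place. They also leave open how a phenyl carrying a methoxy group, a nitrile or an amine would compare.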